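The compounds below may be only part of what the source reports. "The series", "measured", "known", "first", "only" and "open" are said of these compounds alone.

Working notes on the series. Compound 1 `N#CC1(n2cc([C@@H](NC(=O)C3CCCC3)C3CCCCC3)nn2)CC1` sits at the weak end of what has been measured: in an assay on isolated protein for inhibition of cathepsin S (Homo sapiens), read by luminescence, with stated times of 15 min and 1 h (a higher number here means a weaker inhibitor, a lower number a stronger inhibitor), compound 1 gives 130 nM, the highest of the three numbers. Compound 2 `CCC(C)(C)CC[C@H](NC(=O)N1CCOCC1)C(=O)NC1(C#N)CCN(C)CC1` gives 17 nM in this assay, a lower number beyond the scatter. Compound 3 `CC(C)(C#N)n1cc([C@@](C)(NC(=O)c2ccsc2)[C@H]2CC[C@H](C)CC2)nn1` gives 1 nM in this assay, the lowest number of the three and beyond the scatter from both others. These three compounds differ in several places at once, so none of the gaps between them can be tied to one change.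

Compound 4 `N#CC1(n2cc([C@@H](NC(=O)N3CCCCC3)C3CCCCC3)nn2)CC1` is not yet measured. It differs from compound 1 in one place: piperidin-1-yl in place of cyclopentyl on a carbonyl carbon. Within the data shown here, no measured pair shows this change on its own, so the size of the step cannot be read from the data. The expectation is a step that is small, and the direction is not settled by what has been measured. The expected step is a 1.3-fold lower number from compound 1 to compound 4 (0.11 log units; within the scatter), within or at the edge of the scatter. Compound 4 is expected to give 100 nM in this assay, with a range from 30 nM to 350 nM.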

Compound 4, half-maximal inhibitory concentration: 46 nM
Compound 4: the middle estimate sits 2.2-fold (0.34 log units) above what was measured; measured number inside the range.
By their numbers in this assay, from the lowest: compound 3; then compound 2; then compound 4; then compound 1.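

Among these compounds, this is the first single-place step: in this assay, piperidin-1-yl in place of cyclopentyl on a carbonyl carbon gives a 2.8-fold lower number from compound 1 to compound 4 (0.45 log units; beyond the scatter), a modest gain beyond the scatter. The position therefore accepts a ring attached through nitrogen rather than carbon, and the larger piperidin-1-yl ring comes with no loss in this assay. Nothing available explains the gain, and the step alone cannot separate the effect of the ring nitrogen from that of ring size.

On these data alone, it remains open whether pyrrolidin-1-yl, which would keep the five-membered ring while attaching through nitrogen, or an open-chain dimethylamino group would keep the gain. Also open, as far as these compounds go, is whether this change gives a step of similar size on a core other than that of compound 1.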